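From undrawn configuration to S in compound 4

This account rests on a few compounds, and the source may have more. Where it says the series, first, only, none or still open, it means among the compounds named here.

In a functional assay on A-375 cells (Homo sapiens) for antiproliferative activity (on this read-out higher numbers stand for weaker inhibition and lower numbers for stronger inhibition), compound 3 `O=C(Nc1ccc(-c2ccc[nH]2)cc1)C1CCCN(Cc2ccc(F)c(F)c2)C1` stands lowest at 360 nM. Compound 2 `O=C(Nc1ccc(-c2ncc[nH]2)cc1)C1CCCN(Cc2ccc(F)c(F)c2)C1` gives 19000 nM. Compound 1 `O=C(Nc1ccc(-c2c[nH]cn2)cc1)C1CCCN(Cc2ccc(F)c(F)c2)C1` reads > 20000 nM, which is a limit of the assay. Compound 4 `O=C(Nc1ccc(-c2ccc[nH]2)cc1)[C@H]1CCCN(Cc2ccc(F)c(F)c2)C1` departs from compound 3 in one respect: the two compounds have the same atoms and bonds; at least one stereo element is drawn with a configuration in one of them and without one in the other: 1 of 1 stereo elements differ; a stereocentre at a saturated ring carbon is drawn without a configuration in compound 3 and S in compound 4. The measured steps all exchange the ring on the aromatic carbon. Two are large, a 53-fold lower number from compound 2 to compound 3 (1.72 log units; beyond the scatter) and an at least 55-fold lower number from compound 1 to compound 3 (1.74 log units; beyond the scatter), while an at least 1.0-fold lower number from compound 1 to compound 2 (0.02 log units; that floor lies within the scatter) stays within the scatter. Among the measured compounds shown here, none touches a stereocentre, so they show only that numbers in this assay can move widely. A modest move to a lower number is expected, though a higher one cannot be excluded. The expected change is a 2.1-fold lower number from compound 3 to compound 4 (0.33 log units; beyond the scatter). The estimated value for compound 4 is 170 nM, with an expected range from 50 nM to 700 nM.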

Compound 4, half-maximal inhibitory concentration: 190 nM
Compound 4: the middle estimate sits 1.1-fold (0.05 log units) below what was measured; the range from low to high includes it.
By their numbers in this assay, from the lowest: compounds 4 and 3 (each within the scatter of the next); then compound 2. At a limit, above all of these: compound 1.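

In this assay, among the compounds shown here, this is the first step that touches the stereocentre itself, and a 1.9-fold lower number from compound 3 to compound 4 (0.28 log units; within the scatter) stays within the scatter. Compound 4 thus carries the S configuration at the saturated ring carbon without leaving the range of compound 3. The step sets a defined form against an undrawn one, not S against R: the fact that one of compounds 3 and 4 is drawn with a defined configuration and the other without, at the place where they differ

Still open, going by these compounds, is how the R configuration at this carbon would read. So is whether a furan-2-yl group in place of 1H-pyrrol-2-yl on the aromatic carbon would hold the number of compound 4.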